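Replacing the aryl group with a benzamide-bearing chain

A few compounds are considered here, and "the series" means these few. Any claim that something is new, unique, unknown or untested is made for them only; others in the source may bear on it.

Measured so far:
compound 1 `COc1ccc(-c2nnc(SCCCN3CCN(c4nc5ccccc5o4)CC3)o2)cc1` — 52700 nM
compound 2 `c1ccc(-c2nnc(SCCCN3CCN(c4nc5ccccc5o4)CC3)o2)cc1` — 57600 nM

In a functional assay on A-431 cells (Homo sapiens) for inhibition, read by MTT assay, with a stated time of 72 h (on this read-out lower numbers stand for stronger inhibition and higher numbers for weaker inhibition), compound 1 gives 52700 nM, and compound 2 gives 57600 nM. Compound 1 stands alongside compound 2: the step of a 1.1-fold higher number from compound 1 to compound 2 (0.04 log units; within the scatter) shows that the two cannot be told apart on this read-out.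

Compound 3 `O=C(NCc1nnc(SCCCN2CCN(c3nc4ccccc4o3)CC2)o1)c1ccccc1` is to be measured. It differs from compound 1 in one place: benzamidomethyl in place of 4-methoxyphenyl on an aromatic carbon. Among the measured compounds shown here, the only measured step changed just the methoxy on the 4-methoxyphenyl; here the whole 4-methoxyphenyl leaves and a benzamidomethyl enters, so no measured step speaks directly to this change. Both known numbers are weak, and nothing in the data points toward a large move in either direction. The expected step of a 1.2-fold higher number from compound 1 to compound 3 (0.09 log units; within the scatter) is therefore modest. Compound 3 is estimated at 65000 nM, with a range from 20000 nM to 200000 nM.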

Compound 3, half-maximal inhibitory concentration: 36900 nM
Compound 3: middle estimate off by 1.8-fold (0.25 log units), on the high side, within the range that was stated.
By their numbers in this assay, from the lowest: compounds 3, 1 and 2 (each within the scatter of the next).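

The earlier pair showed only that removing a methoxy from the phenyl group makes no readable difference. This result goes further: on this aromatic carbon of the five-membered ring, the whole aryl group can be exchanged for a benzamidomethyl, which brings a carbonyl and an amide hydrogen, and this assay still shows no clear change, with a 1.4-fold lower number from compound 1 to compound 3 (0.15 log units; within the scatter) and a 1.6-fold lower number from compound 2 to compound 3 (0.19 log units; within the scatter). No measurement is available that would explain this insensitivity.

The compounds shown leave open whether any group on this carbon can produce a step beyond the scatter, for instance an amine or a carboxylic acid. They also leave open whether a longer chain in place of the methylene of the benzamidomethyl would do so.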